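A few compounds are considered here, and "the series" means these few. Any claim that something is new, unique, unknown or untested is made for them only; others in the source may bear on it.

Compound 1 `CCCOc1ccc(C(O)C2OC(=O)c3c(OC)cc(OC)cc32)cc1`: > 40000 nM
Compound 2 `CCCCOc1ccc(C(O)C2OC(=O)c3c(OC)cc(OC)cc32)cc1`: > 40000 nM

Compound 1 and compound 2 share the same core and differ only in the chain on the aromatic oxygen. In an ADME assay on RAW264.7 cells (Mus musculus) for cytotoxicity, read by MTT assay, with a stated time of 24 h, in the absence of a further agent (a lower number here means a stronger inhibitor, a higher number a weaker inhibitor), compound 1 gives > 40000 nM, which is a limit of the assay and not a number. In this assay compound 2 gives > 40000 nM, again a limit rather than a measured figure. The step that the two limits leave unreadable from compound 1 to compound 2 therefore cannot be read in either size or direction. Both results sit at the limit of > 40000 nM in this assay, at which 2 of the 2 values shown sit. Compound 2 thus stands at the limit of this assay, with no number of its own.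

Compound 3 `COc1cc(OC)c2c(c1)C(C(O)c1ccc(OCC3CCCCC3)cc1)OC2=O` differs from compound 2 by cyclohexyl in place of propyl on a saturated chain carbon bound to an oxygen on an aromatic ring. For the measured compounds named here, the only measured step, from compound 1 to compound 2, concerns the same chain and is unreadable, so it gives no size and no direction to carry over; what the two measured compounds show is simply that both chain variants stay at the limit. Compound 3 is expected to remain at the limit as well, the expected step being a step that the limit leaves unreadable from compound 2 to compound 3. The estimate for compound 3 in this assay is 60000 nM, with a range from 25000 nM to 150000 nM.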

Compound 3, half-maximal inhibitory concentration: > 40000 nM
Compound 3 ended at the assay's limit; the forecaster's own chance of this, stated with the estimate: 80%; the middle value does not contradict the limit.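

In this assay compound 3 gives > 40000 nM, which is again a limit of the assay and not a number. For the compounds shown here, no step among compound 1, compound 2 and compound 3 can be read, in either size or direction: the limit of > 40000 nM in this assay, at which 3 of the 3 values shown sit. What the compounds shown leave open is whether the chain on the aromatic oxygen makes any difference in this assay at all.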